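The source may report more compounds than this note shows. Statements on the series, on what has been measured and on what is new or still open speak of the compounds shown alone.

Of the compounds shown here, three sharing one core have been measured in an assay on isolated protein for inhibition of Indoleamine 2,3-dioxygenase 1 (Homo sapiens), read by spectrophotometry; a lower number here means a stronger inhibitor, a higher number a weaker inhibitor. Compound 1 `O/N=C(/Nc1ccccc1)c1ccc2occc2c1` carries only hydrogen at the position of interest, and in this assay compound 1 reaches only the assay's limit of > 30000 nM, which is not a number. Compound 2 `O/N=C(/Nc1cccc(Br)c1)c1ccc2occc2c1` has bromo at that place, and in this assay compound 2 gives 440 nM; the step of an at least 68-fold lower number from compound 1 to compound 2 (1.83 log units; beyond the scatter) is large. Compound 3 `CC1CCN(C(=O)c2cccc(N/C(=N/O)c3ccc4occc4c3)c2)CC1` carries (4-methylpiperidin-1-yl)carbonyl instead, and for compound 3 this assay again reports only its limit, > 30000 nM. On the numbers shown, compound 3 sits at the weak end, resting at the limit of > 30000 nM in this assay, at which 2 of the 3 values shown sit. The step of an at least 68-fold higher number from compound 2 to compound 3 (1.83 log units; beyond the scatter) is large, while a step that the two limits leave unreadable from compound 1 to compound 3.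

Compound 4 `O/N=C(/Nc1cccc(Oc2ccccc2)c1)c1ccc2occc2c1` differs from compound 3 by phenoxy in place of (4-methylpiperidin-1-yl)carbonyl on an aromatic carbon. The readable steps show that hydrogen or the carbonyl group leaves inhibition too weak to read, whereas bromo brings it to a measured value, so a phenoxy group at the same place is expected to move toward compound 2 rather than stay at the limit. Compound 4 is therefore estimated at 1500 nM, between 200 nM and 15000 nM, which means an expected step of an at least 20-fold lower number from compound 3 to compound 4 (1.30 log units; beyond the scatter).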

Compound 4, half-maximal inhibitory concentration: > 30000 nM
Compound 4 gave a limit, no number; the forecaster's own chance of this, stated with the estimate: 20%; at least 20-fold (1.30 log units) between middle value and limit.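

In this assay, putting phenoxy in place of bromo loses the measured inhibition, with an at least 68-fold higher number from compound 2 to compound 4 (1.83 log units; beyond the scatter). At this place an aromatic ring joined through oxygen in compound 4 fares no better on the numbers shown than the carbonyl-linked, non-aromatic ring of compound 3, so a large group need not carry that carbonyl to lose readable inhibition, and only bromo in compound 2 gives a number, against compound 1, compound 3 and compound 4. The result for compound 4 is a limit, not a number, so its steps to compound 1 and compound 3 cannot be read, and these three compounds cannot be ranked: the limit of > 30000 nM in this assay, at which 3 of the 4 values shown sit.

The compounds shown leave open whether chloro or methyl at this place would also give a measured value. They also leave open whether methoxy, which keeps the oxygen of phenoxy but not its ring, would do so.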